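Removing a methoxy group from a chalcone-like series

A few compounds are considered here, and "the series" means these few. Any claim that something is new, unique, unknown or untested is made for them only; others in the source may bear on it.

Measured compounds:
compound 1, `COc1cc(OC)c(C(=O)/C=C/c2cn(-c3ccccc3)nc2-c2ccsc2)c(OC)c1`: 5200 nM
compound 2, `COc1ccc(C(=O)/C=C/c2cn(-c3ccccc3)nc2-c2ccsc2)c(OC)c1`: 2200 nM
compound 3, `COc1ccc(C(=O)/C=C/c2cn(-c3ccccc3)nc2-c2cccnc2)c(OC)c1OC`: 1100 nM

These three compounds were tested in a functional assay on HCT-116 cells (Homo sapiens) for inhibition, read by sulforhodamine B assay, with a stated time of 72 h; a higher number here means a weaker inhibitor, a lower number a stronger inhibitor. Compound 2 differs from compound 1 only by hydrogen in place of methoxy on an aromatic carbon, and this brought a 2.4-fold lower number from compound 1 to compound 2 (0.37 log units; beyond the scatter). Compound 3 gives the lowest number of the three, though its distance from compound 2 lies within the scatter. How the core of compound 3 differs from that of compound 1 is not broken down here.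

Compound 4, `COc1ccc(C(=O)/C=C/c2cn(-c3ccccc3)nc2-c2cccnc2)cc1OC`, is not yet measured; it differs from compound 3 by hydrogen in place of methoxy on an aromatic carbon. This is the same kind of change as that from compound 1 to compound 2, but the surroundings differ: in compound 3 the removed methoxy sits ortho to a methoxy group and meta to a methoxy group, whereas in compound 1 it sat meta to two methoxy groups. Because compound 2 showed a 2.4-fold lower number from compound 1 to compound 2 (0.37 log units; beyond the scatter), a step of similar size is expected here, a 2.0-fold lower number from compound 3 to compound 4 (0.30 log units; within the scatter), with wide bounds since the surroundings are not identical. Compound 4 is therefore estimated at 550 nM, most likely between 250 nM and 1300 nM.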

Compound 4, half-maximal inhibitory concentration: 4300 nM
Compound 4: the middle estimate sits 7.8-fold (0.89 log units) below what was measured; measured number above the stated range.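

Replacing a methoxy group with hydrogen gave a 3.9-fold higher number from compound 3 to compound 4 (0.59 log units; beyond the scatter), the opposite direction to the earlier step, so the two cores did not respond alike: the same change on two cores in this assay, a 2.4-fold lower number (0.37 log units; beyond the scatter) from compound 1 to compound 2 and a 3.9-fold higher number (0.59 log units; beyond the scatter) from compound 3 to compound 4, 9.2-fold (0.97 log units) apart, beyond the scatter of two such steps

The effect of this change on one core therefore cannot simply be carried over to another core in this series. These two pairs do not show what sets the direction, however, as they differ both in the core and in the surroundings of the removed methoxy group, and two pairs make no general rule.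

From the compounds shown here alone, it remains open which of those differences matters. Going by these compounds, it is also open whether another group in the same place, such as a hydroxyl group or an amine, would behave like methoxy or like hydrogen.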